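The source may report more compounds than this note shows. Statements on the series, on what has been measured and on what is new or still open speak of the compounds shown alone.

Of the compounds shown here, three sharing one core have been measured in an in vitro ADME assay on microsomes from liver (Homo sapiens) for metabolic stability; on this read-out lower numbers stand for slow clearance and higher numbers for fast clearance: compound 1 `O=C(COCc1ccccc1)N1CCN(c2ccccc2Cl)CC1` gives 540 mL.min-1.g-1, compound 2 `O=C(COCc1ccccc1)N1CCN(c2cccc(Cl)c2)CC1` gives 310 mL.min-1.g-1, and compound 3 `O=C(COCc1ccccc1)N1CCN(c2ccc(F)cc2)CC1` gives 110 mL.min-1.g-1, the lowest of the three. Compound 4 `O=C(COCc1ccccc1)N1CCN(c2ccc(F)cc2F)CC1` differs from compound 3 in one place: fluoro in place of hydrogen on an aromatic carbon. Within the data shown here, no measured step makes this exact change. The nearest evidence is a 4.9-fold lower number from compound 1 to compound 3 (0.69 log units; beyond the scatter) and a 2.8-fold lower number from compound 2 to compound 3 (0.45 log units; beyond the scatter), both modest, while a 1.7-fold lower number from compound 1 to compound 2 (0.24 log units; within the scatter) lies within the scatter. Only a small rise, within the scatter, is therefore expected, and the estimated step is a 1.2-fold higher number from compound 3 to compound 4 (0.07 log units; within the scatter). Compound 4 is estimated at 130 mL.min-1.g-1, with an expected range from 65 mL.min-1.g-1 to 260 mL.min-1.g-1.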

Compound 4, intrinsic clearance in microsomes: 580 mL.min-1.g-1
Compound 4: the middle estimate sits 4.5-fold (0.65 log units) below what was measured; the whole stated range lies below it.
By their numbers in this assay, from the lowest: compound 3; then compounds 2, 1 and 4 (each within the scatter of the next).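

On the ring of compound 3, one fluoro ortho to a large group, turning 4-fluorophenyl into 2,4-difluorophenyl, clearly shifts the read-out in this assay (a 5.3-fold higher number from compound 3 to compound 4 (0.72 log units; beyond the scatter)). So a single added heavy atom at this position can undo the low number of compound 3. The 2,4-difluorophenyl compound also cannot be told apart from either chlorophenyl compound (a 1.9-fold higher number from compound 2 to compound 4 (0.27 log units; within the scatter); a 1.1-fold higher number from compound 1 to compound 4 (0.03 log units; within the scatter)). From the compounds shown here alone, whether a methyl or methoxy group at this position would act like fluoro stays open. Nothing available explains the shift.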